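The source may report more compounds than this note shows. Statements on the series, on what has been measured and on what is new or still open speak of the compounds shown alone.

Measured so far:
- compound 1, `COc1ccc(Nc2ncnc3cc(OC)c(OCCCCC(=O)Nc4ccc(S(N)(=O)=O)cc4)cc23)cc1`: 30200 nM
- compound 2, `COc1cc2ncnc(Nc3cc(F)c(F)c(F)c3)c2cc1OCCCCC(=O)Nc1ccc(S(N)(=O)=O)cc1`: 20000 nM

In a functional assay on NCI-H1975 cells (Homo sapiens) for antiproliferative activity, read by MTT assay, with a stated time of 72 h (on this read-out lower numbers stand for stronger inhibition and higher numbers for weaker inhibition), compound 2 is separated from compound 1 only by a 1.5-fold lower number from compound 1 to compound 2 (0.18 log units; within the scatter), so the two stand level within the scatter, and no real ordering between them is shown. Compound 3, `COc1cc2ncnc(Nc3ccc(C)cc3)c2cc1OCCCCC(=O)Nc1ccc(S(N)(=O)=O)cc1`, changes the same place: 4-methylphenyl in place of 3,4,5-trifluorophenyl on a nitrogen on an aromatic ring. Among the measured compounds shown here, the one measured step that touches this place, a 1.5-fold lower number from compound 1 to compound 2 (0.18 log units; within the scatter), shows that swapping the group there hardly moved the number. A step of a 1.3-fold higher number from compound 2 to compound 3 (0.10 log units; within the scatter) is therefore expected, none beyond the scatter. Compound 3 is estimated at 25000 nM, in the range 10000 nM to 60000 nM.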

Compound 3, half-maximal inhibitory concentration: 19300 nM
Estimate against measurement, compound 3: 1.3-fold (0.11 log units) above, within the range that was stated.
By their numbers in this assay, from the lowest: compounds 3, 2 and 1 (each within the scatter of the next).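

Across 4-methoxyphenyl, 3,4,5-trifluorophenyl and 4-methylphenyl on this nitrogen, this assay shows no separation: there is a 1.0-fold lower number from compound 2 to compound 3 (0.02 log units; within the scatter) and also a 1.6-fold lower number from compound 1 to compound 3 (0.19 log units; within the scatter) between the two compounds that differ by methyl in place of methoxy. A third aromatic group therefore extends the flat picture, with neither the fluorines nor the methyl standing apart. No measured evidence bears on this result.

Open, going by these compounds, is whether a group of another kind here, such as a pyridine ring or a benzyl group, would move the number. Also open, on these data alone, is whether a carboxylic acid in place of the sulfonamide, or a longer chain, would do so.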